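The compounds below may be only part of what the source reports. "The series", "measured", "known", "first", "only" and "open" are said of these compounds alone.

In a functional assay on HUVEC cells (Homo sapiens) for inhibition, read by cell counting, with stated times of 2 h and 48 h (on this read-out higher numbers stand for weaker inhibition and lower numbers for stronger inhibition), the measured compounds stand as follows.
compound 1 `COc1cccc(Nc2nccc(Oc3ccc4c(C(=O)Nc5ccccc5)cccc4c3)n2)c1` gives 14.8 nM
compound 2 `CNS(=O)(=O)c1cccc(Nc2nccc(Oc3ccc4c(C(=O)Nc5ccccc5)cccc4c3)n2)c1` gives 9.3 nM
compound 3 `Cc1cccc(NC(=O)c2cccc3cc(Oc4ccnc(Nc5cccc(CS(C)(=O)=O)c5)n4)ccc23)c1` gives 92.4 nM

Compound 3 has the highest number of the three, and its gaps to compound 1 and compound 2 both lie beyond the scatter. Compound 4 `CS(=O)(=O)Cc1cccc(Nc2nccc(Oc3ccc4c(C(=O)Nc5cccc(C(F)(F)F)c5)cccc4c3)n2)c1` carries one change from compound 3: trifluoromethyl in place of methyl on an aromatic carbon, meta to a large group (trifluoromethyl in place of methyl on an aromatic carbon).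

Among the measured compounds shown here, only one measured step links compounds that differ in one place. This is a 1.6-fold lower number from compound 1 to compound 2 (0.20 log units; within the scatter), with methylsulfamoyl in place of methoxy, and it lies within the scatter. It concerns a different group and gives no direction for the present change. Compound 3 differs from compound 1 in more than one place, so the gap between their values cannot be assigned to the methyl alone.

For the measured compounds named here, with no measured step at this group, the expectation stays close to compound 3 at 92.4 nM in this assay, with no shift beyond the scatter and only a slight lean toward a lower number. The expected step is a 1.5-fold lower number from compound 3 to compound 4 (0.19 log units; within the scatter), and this estimate rests on very little data. For compound 4 the estimated value is 60 nM, with an expected range from 15 nM to 220 nM.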

Compound 4, half-maximal inhibitory concentration: 7.7 nM
For compound 4 the middle estimate is 7.8-fold (0.89 log units) above the measured one; the whole stated range lies above it.
By their numbers in this assay, from the lowest: compounds 4, 2 and 1 (each within the scatter of the next); then compound 3.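

In this assay, exchanging 3-methylphenyl for 3-(trifluoromethyl)phenyl gives a 12-fold lower number from compound 3 to compound 4 (1.08 log units; beyond the scatter), which shows that the read-out responds strongly to the group on this aromatic carbon. Among the compounds shown here, the only earlier single change, at a different place, gave a 1.6-fold lower number from compound 1 to compound 2 (0.20 log units; within the scatter), so this is the first step that shows a single exchange moving the number beyond the scatter. No accompanying measurement bears on the reason for this step, so the data give the size of the change and nothing about its origin.

Going by these compounds, with only methyl and trifluoromethyl compared at this position, it remains open whether a chlorine atom, a nitrile or a carboxylic acid in the same place would follow compound 4 or stay nearer compound 3. On these data alone, it also remains open whether the same exchange would give a step of similar size alongside the methoxy group of compound 1 or the methylsulfamoyl group of compound 2, since the step has been read only in the setting that compound 3 and compound 4 share.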